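This account rests on a few compounds, and the source may have more. Where it says the series, first, only, none or still open, it means among the compounds named here.

Measured so far:
Compound 1 `Cc1nc2ccccn2c1CSCCNc1n[s+]([O-])nc1N` in a functional assay on the whole organism (stomach) with Rattus norvegicus as the target (on this read-out higher numbers stand for an effect only at larger amounts of compound and lower numbers for an effect already at smaller amounts), gives >> 25 mg/kg, which is a limit of the assay and not a number.
Compound 2 `Cc1nc2ccccn2c1C(C)SCCNc1n[s+]([O-])nc1N` in this assay gives >> 25 mg/kg, again a limit of the assay.
Compound 3 `Cc1nc2ccccn2c1CSCCNc1nsnc1N` in this assay gives >> 25 mg/kg, also a limit of the assay.

Compound 4 `Cc1nc2ccccn2c1C(C)SCCNc1nsnc1N` has not yet been measured in this assay.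

The change from compound 1 to compound 2 is methyl in place of hydrogen on a saturated chain carbon bound to an aromatic carbon and a sulfur. Its effect on this assay is a step that the two limits leave unreadable from compound 1 to compound 2. The two cores differ as follows: a group of 6 heavy atoms (2 carbon, 3 nitrogen, 1 sulfur; one five-membered aromatic ring with 3 hetero atoms) in place of a group of 7 heavy atoms (2 carbon, 3 nitrogen, 1 oxygen, 1 sulfur; one five-membered aromatic ring with 3 hetero atoms), on an amine nitrogen. The step that goes with this is a step that the two limits leave unreadable from compound 1 to compound 3. The change from compound 3 to compound 4 is methyl in place of hydrogen on a saturated chain carbon bound to an aromatic carbon and a sulfur. Its place line reads word for word like that of the change from compound 1 to compound 2, so it is the same change made on the other core.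

What the measurements offer is only this: the limit of >> 25 mg/kg in this assay, at which 3 of the 3 values shown sit. Going by the values given here, because the limit of >> 25 mg/kg in this assay, at which 3 of the 3 values shown sit, every value shown sits at the limit, no measured step has a readable size, and the change from compound 1 to compound 2 shows nothing that could be carried over to compound 4.

The step from compound 3 to compound 4 is therefore expected to be a step that the limit leaves unreadable from compound 3 to compound 4, resting only on the observation that compound 3 and compound 2 both sit at the limit and no shown step has a readable size. For compound 4 the expected value in this assay is 60 mg/kg, most likely reported again as a limit only, with a range from 25 mg/kg to 300 mg/kg if a number is obtained.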

Compound 4, dose for half-maximal effect: >> 25 mg/kg
Compound 4: a limit, no number; the forecaster's own chance of this, stated with the estimate: 90%; the middle value does not contradict the limit.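

In this assay compound 4 gives >> 25 mg/kg, a limit of the assay and not a number. Neither step to compound 4, from compound 3 or from compound 2, can be read, and the four compounds share one result: the limit of >> 25 mg/kg in this assay, at which 4 of the 4 values shown sit.

The compounds shown leave open how large the effect of the methyl in place of hydrogen or of the change of core is, and at what dose any of them reaches half-maximal effect.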